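The source may report more compounds than this note shows. Statements on the series, on what has been measured and on what is new or still open speak of the compounds shown alone.

Working notes on the hydroxyphenyl nicotinoyl series. In a functional assay on IMR-32 cells (Homo sapiens) for cytotoxicity, read by sulforhodamine B assay, with a stated time of 48 h (on this read-out lower numbers stand for stronger inhibition and higher numbers for weaker inhibition), compound 1 `O=C(c1cccnc1)c1ccccc1O` gives 33700 nM. Among the three measured compounds it stands second highest: compound 3 `O=C(c1cccnc1)c1cccc(Cl)c1O` gives 26000 nM, and the step of a 1.3-fold lower number from compound 1 to compound 3 (0.11 log units; within the scatter) is within the scatter; compound 2 `O=C(c1cccnc1)c1ccc(Br)cc1O` gives 89000 nM, and the step of a 2.6-fold higher number from compound 1 to compound 2 (0.42 log units; beyond the scatter) is beyond it, a modest weakening.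

Compound 4 `O=C(c1cccnc1)c1cc(Cl)ccc1O` is not yet measured. It differs from compound 1 by chloro in place of hydrogen on an aromatic carbon. The two steps on record that bear on it both put a halogen in place of hydrogen on the shared core: bromo gave a modest higher number, chloro gave a change within the scatter. Within the data shown here, neither speaks directly to this place on the ring, and with only two halogen steps no pattern can be claimed. The expectation is therefore a step of at most modest size, more likely toward a higher number than a lower one, and quite possibly none beyond the scatter. Compound 4 is thus estimated at 40000 nM in this assay, with a range from 18000 nM to 90000 nM, which implies an expected step of a 1.2-fold higher number from compound 1 to compound 4 (0.07 log units; within the scatter).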

Compound 4, half-maximal inhibitory concentration: 19500 nM
For compound 4 the middle estimate is 2.1-fold (0.31 log units) above the measured one; the measured number falls inside the stated range.
By their numbers in this assay, from the lowest: compounds 4, 3 and 1 (each within the scatter of the next); then compound 2.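

In this assay, chloro in place of hydrogen on the aromatic carbon para to a hydroxy group gives a 1.7-fold lower number from compound 1 to compound 4 (0.24 log units; within the scatter), so at this place the change does not separate compound 4 from compound 1. Among these compounds, with a 1.3-fold lower number from compound 1 to compound 3 (0.11 log units; within the scatter), both chloro steps on the shared core now lie within the scatter, while the only step beyond it remains a 2.6-fold higher number from compound 1 to compound 2 (0.42 log units; beyond the scatter); that bromo step sits at a different place, so the halogen and its place cannot be told apart. No supporting data bear on why these steps fall as they do.

On these data alone, whether bromo at this same place would match the chloro step remains open, as does whether an amine or a carboxylic acid there would move the number beyond the scatter. The compounds shown also leave open what a methoxy group in place of the hydroxy group would do.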